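The source may hold more compounds than are shown below. What is called first, only, known or untested is meant among the compounds shown, and "the series" means these compounds.

Measured so far in a functional assay on the whole organism for inhibition, with Rattus norvegicus as the target (a lower number here means that less compound is needed, a higher number that more compound is needed for the effect), with both entries limits and not numbers:
compound 1 `O=C(O)C(Cc1ccc(Cl)cc1)Oc1ccccc1` gives > 25 mg/kg (a limit)
compound 2 `Cc1ccc(OC(Cc2ccc(Cl)cc2)C(=O)O)cc1` gives > 25 mg/kg (a limit)

Compound 2 therefore has no number to stand on, only its limit. Among the measured compounds shown here, the whole series so far is the limit of > 25 mg/kg in this assay, at which 2 of the 2 values shown sit, and offers no ranking. The next structure is compound 3 `COc1ccc(OC(Cc2ccc(Cl)cc2)C(=O)O)cc1`, with methoxy in place of methyl on an aromatic carbon, para to a large group methoxy in place of methyl on an aromatic carbon as the one difference. For the measured compounds named here, the only measured step bearing on this place is a step that the two limits leave unreadable from compound 1 to compound 2 and it gives no size to carry forward. No step beyond the scatter can be argued from it, and another limit is the likelier report. The expected step is a step that the limit leaves unreadable from compound 2 to compound 3 and this expectation is loose. For compound 3 the estimate is 30 mg/kg with an expected range from 12 mg/kg to 75 mg/kg in this assay as the read-out.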

Compound 3, dose for half-maximal effect: > 25 mg/kg
Compound 3: no number, only a limit (the forecaster's own chance of this, stated with the estimate: 70%); the middle value lies beyond the limit too.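

No step can be read among compound 1, compound 2 and compound 3 in this assay, since each gives only a limit and not a number: the limit of > 25 mg/kg in this assay, at which 3 of the 3 values shown sit.

As far as these compounds go, whether hydrogen, methyl or methoxy on the aromatic carbon makes any difference to the dose needed remains open.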